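Ring substituent variation on the shared core

The compounds below may be only part of what the source reports. "The series", "measured", "known", "first", "only" and "open" are said of these compounds alone.

Measured compounds in an assay for binding affinity to Indoleamine 2,3-dioxygenase 1 (Homo sapiens), read by spectrophotometry, with a stated time of 30 min; on this read-out lower numbers stand for tighter binding and higher numbers for weaker binding:
- compound 1, `OC(Cc1ccccc1)c1cccc2[nH]ncc12`: 31000 nM
- compound 2, `OC(Cc1ccccc1)c1cc(Br)cc2[nH]ncc12`: 600 nM
- compound 3, `C#Cc1cc(C(O)Cc2ccccc2)c2cn[nH]c2c1`: 7400 nM

Compound 1, the unsubstituted parent, gives the highest number of the three in this assay. Both substituted analogues lie beyond the scatter below it: a 52-fold lower number from compound 1 to compound 2 (1.71 log units; beyond the scatter), and a 4.2-fold lower number from compound 1 to compound 3 (0.62 log units; beyond the scatter). Between the two substituents, a 12-fold higher number from compound 2 to compound 3 (1.09 log units; beyond the scatter), so the gain depends on which group sits at this position.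

Compound 4, `CCc1cc(C(O)Cc2ccccc2)c2cn[nH]c2c1`, is not yet measured. The change from compound 1 is ethyl in place of hydrogen on an aromatic carbon. The two relevant steps are those to compound 2 and compound 3, both at the same position, both lowering the number, one large and one modest. Among the compounds with values here, an ethyl group has no measured precedent here, so the expectation is drawn from the span between those two steps rather than from either alone. In this assay compound 4 is expected to show a 5.2-fold lower number from compound 1 to compound 4 (0.71 log units; beyond the scatter). The estimate for compound 4 is 6000 nM, with a range of 1500 nM to 20000 nM.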

Compound 4, dissociation constant: 1100 nM
Beside the measured number, compound 4's estimate is 5.5-fold (0.74 log units) above it; measured number outside the range, below it.
By their numbers in this assay, from the lowest: compounds 2 and 4 (each within the scatter of the next); then compound 3; then compound 1.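

In this assay, ethyl at this position also gives a large step (a 28-fold lower number from compound 1 to compound 4 (1.45 log units; beyond the scatter)), so a large drop in the number is not confined to bromo among the groups shown. Ethyl and bromo cannot be separated here (a 1.8-fold higher number from compound 2 to compound 4 (0.26 log units; within the scatter)), whereas ethyl and ethynyl can (a 6.7-fold lower number from compound 3 to compound 4 (0.83 log units; beyond the scatter)), which shows that two groups of the same carbon count can give clearly different numbers at this position. The data shown contain nothing that accounts for these differences.

As far as these compounds go, it remains open how a longer chain such as propyl, a branched group such as isopropyl, or an amine or a carboxylic acid would behave at this position. Whether chloro or iodo would track with bromo is also unresolved.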